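A few compounds are considered here, and "the series" means these few. Any claim that something is new, unique, unknown or untested is made for them only; others in the source may bear on it.

Compound 1 `CONC(=S)N/N=C1\C(=O)N(CN2CCN(c3ccccc3)CC2)c2ccc(F)cc21`: 227000 nM
Compound 2 `CONC(=S)N/N=C1\C(=O)N(CN2CCN(c3ccc(Cl)cc3)CC2)c2ccc(F)cc21`: 347000 nM

Both values come from an ADME assay on MT4 cells (Homo sapiens) for cytotoxicity, read by spectrophotometry, with a stated time of 5 days; on this read-out higher numbers stand for lower toxicity in this test and lower numbers for higher toxicity in this test. The two compounds share one core and differ only in a single substituent on an aromatic carbon. Compound 2 carries chloro where compound 1 has hydrogen, and the measured step is a 1.5-fold higher number from compound 1 to compound 2 (0.18 log units; within the scatter). Among the measured compounds shown here, compound 2 therefore stands within the scatter of compound 1, the only other compound measured.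

The next compound is compound 3 `CONC(=S)N/N=C1\C(=O)N(CN2CCN(c3ccc(OC)cc3)CC2)c2ccc(F)cc21`, which has not yet been measured. It differs from compound 2 at that same carbon, with methoxy in place of chloro on an aromatic carbon. The swap is 4-chlorophenyl to 4-methoxyphenyl, and the rest of the molecule is unchanged.

For the measured compounds named here, only one measured step bears on this place, a 1.5-fold higher number from compound 1 to compound 2 (0.18 log units; within the scatter), and no measured compound carries methoxy. With so small a precedent, no shift beyond the scatter is expected in this assay, and no direction can be firmly called. The expected step is a 1.2-fold lower number from compound 2 to compound 3 (0.09 log units; within the scatter).

For compound 3 the estimated value is 280000 nM, with an expected range from 140000 nM to 500000 nM.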

Compound 3, half-maximal cytotoxic concentration: 276000 nM
The estimate for compound 3 lay 1.0-fold (0.01 log units) above the measured number; the measured number falls inside the stated range.
By their numbers in this assay, from the lowest: compounds 1, 3 and 2 (each within the scatter of the next).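

In this assay, the position on the aromatic carbon para to a large group has now carried a second substituent, and one of a different kind from chloro. Methoxy in place of chloro gives a 1.3-fold lower number from compound 2 to compound 3 (0.10 log units; within the scatter) and methoxy in place of hydrogen gives a 1.2-fold higher number from compound 1 to compound 3 (0.08 log units; within the scatter) as its step, so hydrogen, chloro and methoxy all stand within the scatter of each other, even though methoxy adds a hydrogen-bond acceptor and has more heavy atoms than chloro. Nothing on hand bears on why this change leaves the read-out within the scatter.

Going by these compounds, whether an amine, a carboxylic acid or a longer chain such as butoxy on this same carbon would give a step beyond the scatter remains open, since the three groups seen here cover only a narrow set of substituents at this place. Also open, on these data alone, is whether changes elsewhere on the shared core, or a group other than phenyl on the piperazine nitrogen, would move the number in this test.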